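The compounds below may be only part of what the source reports. "The series", "measured", "known", "first", "only" and "open" are said of these compounds alone.

In a functional assay on PC-3 cells (Homo sapiens) for antiproliferative activity, read by WST assay, with a stated time of 3 days (a lower number here means a stronger inhibitor, a higher number a weaker inhibitor), compound 1 (`CCCCCCOc1c(-c2cc(OC)c(OC)c(OC)c2)oc2ccccc2c1=O`) gives 29200 nM, compound 2 (`COc1cc(-c2oc3ccccc3c(=O)c2OC(C)C)cc(OC)c1OC`) gives 21200 nM and compound 3 (`CCCN(CCC)CCCOc1c(-c2cc(OC)c(OC)c(OC)c2)oc2ccccc2c1=O`) gives 16800 nM. Compound 3 stands within the scatter of both other compounds, as shown by a 1.7-fold lower number from compound 1 to compound 3 (0.24 log units; within the scatter) and a 1.3-fold lower number from compound 2 to compound 3 (0.10 log units; within the scatter). The remaining measured step, a 1.4-fold lower number from compound 1 to compound 2 (0.14 log units; within the scatter), also stays within the scatter.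

Compound 4 (`CCCCN(CCCC)CCCOc1c(-c2cc(OC)c(OC)c(OC)c2)oc2ccccc2c1=O`) has dibutylamino in place of dipropylamino on a saturated chain carbon, three bonds along the chain from an oxygen on an aromatic ring. The nearest evidence is the change at this same place, dipropylamino in place of propyl, which gave a 1.7-fold lower number from compound 1 to compound 3 (0.24 log units; within the scatter). The replacement of isopropyl by 3-(dipropylamino)propyl on the oxygen gave a 1.3-fold lower number from compound 2 to compound 3 (0.10 log units; within the scatter). Within the data shown here, neither step leaves the scatter, but no measured pair compares dipropylamino directly with dibutylamino. No step beyond the scatter is therefore expected in this assay. The expected step is a 1.1-fold lower number from compound 3 to compound 4 (0.02 log units; within the scatter). The estimated value for compound 4 is 16000 nM, within an expected range of 8000 nM to 32000 nM.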

Compound 4, half-maximal inhibitory concentration: 7100 nM
Beside the measured number, compound 4's estimate is 2.3-fold (0.35 log units) above it; the measured number lies below the stated range.
By their numbers in this assay, from the lowest: compound 4; then compounds 3, 2 and 1 (each within the scatter of the next).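

In this assay, among these compounds, dibutylamino in place of dipropylamino on a saturated chain carbon, three bonds along the chain from an oxygen on an aromatic ring, gives a 2.4-fold lower number from compound 3 to compound 4 (0.37 log units; beyond the scatter) and is the first step to leave the scatter, so this place responds to a change within the amine itself and not only to a change of the whole side chain. The 3-(dibutylamino)propyl chain also separates from isopropyl with a 3.0-fold lower number from compound 2 to compound 4 (0.48 log units; beyond the scatter) and from hexyl with a 4.1-fold lower number from compound 1 to compound 4 (0.61 log units; beyond the scatter) while the three earlier side chains stay within the scatter of one another. Nothing at hand accounts for these steps.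

As far as these compounds go, whether dipentylamino at the same place would extend the trend stays open, since a single pair of amines supports no trend yet. From the compounds shown here alone, a ring amine such as piperidin-1-yl also remains untested against dibutylamino in these notes.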